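A few compounds are considered here, and "the series" means these few. Any claim that something is new, unique, unknown or untested is made for them only; others in the source may bear on it.

Working notes on the series: the compounds share one core and a long chain ending in an amide, and only the aromatic group on the carbonyl carbon varies. In a functional assay on HBC5 cells (Homo sapiens) for inhibition, read by colorimetric assay and sulforhodamine B assay, with a stated time of 48 h (on this read-out lower numbers stand for stronger inhibition of growth and higher numbers for weaker inhibition of growth), compound 1 (`CCCCCCCCCCCC[C@@H](O)[C@H]1CC[C@H]([C@H](O)CCCCCCCCCCNC(=O)c2cccs2)O1`) gives 3240 nM, and compound 2 (`CCCCCCCCCCCC[C@@H](O)[C@H]1CC[C@H]([C@H](O)CCCCCCCCCCNC(=O)c2ccsc2)O1`) gives 2090 nM. Among the compounds with values here, compound 2 therefore stands level with compound 1, the only other measured member. Compound 3 (`CCCCCCCCCCCC[C@@H](O)[C@H]1CC[C@H]([C@H](O)CCCCCCCCCCNC(=O)c2ccnn2C)O1`) is unmeasured and keeps everything except that group: 1-methyl-1H-pyrazol-5-yl in place of thiophen-3-yl on a carbonyl carbon. In words, this is 1-methyl-1H-pyrazol-5-yl in place of thiophen-3-yl on a carbonyl carbon.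

Within the data shown here, one measured step bears on this change, at the same place: a 1.6-fold lower number from compound 1 to compound 2 (0.19 log units; within the scatter). It only exchanges thiophen-2-yl for thiophen-3-yl, so it is a limited guide to a change of ring. Among the measured compounds shown here, no measured compound carries 1-methyl-1H-pyrazol-5-yl, and the data give no direction. No step beyond the scatter is therefore expected in this assay. The expected change is a 1.3-fold higher number from compound 2 to compound 3 (0.13 log units; within the scatter). The estimated value for compound 3 is 2800 nM, with an expected range from 1300 nM to 6500 nM.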

Compound 3, concentration for 50% growth inhibition: 17000 nM
The estimate for compound 3 lay 6.1-fold (0.78 log units) below the measured number; measured number outside the range, above it.
By their numbers in this assay, from the lowest: compounds 2 and 1 (each within the scatter of the next); then compound 3.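

In this assay, the group on the carbonyl carbon turns out not to be indifferent to the identity of the ring: 1-methyl-1H-pyrazol-5-yl gives an 8.1-fold higher number from compound 2 to compound 3 (0.91 log units; beyond the scatter) and a 5.2-fold higher number from compound 1 to compound 3 (0.72 log units; beyond the scatter), whereas the exchange between the two thiophen-yl groups stayed within the scatter. Both new steps point towards weaker inhibition of growth, so compound 3 stands apart from compound 1 and compound 2, and a five-membered aromatic ring at this place is not enough on its own to keep the level of those two compounds. No measurement at hand gives a reason for this step.

The compounds shown do not separate the part played by the two ring nitrogens from that of the methyl group, so it remains open how a pyrazolyl ring without the methyl, a phenyl ring or a pyridinyl ring would read at this place. Going by these compounds, it also remains open whether the same exchange would give a step of similar size on a shorter chain than the one shared here.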